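The source may report more compounds than this note shows. Statements on the series, on what has been measured and on what is new or still open speak of the compounds shown alone.

Within the data shown here, compound 2 `CCC(C)C(C)/N=C(\NC#N)Nc1ccncc1` holds the lower of the two numbers measured so far in a functional assay on the whole organism (blood, strain Wistar-Okamoto) with Rattus norvegicus as the target, with a stated time of 5 days; on this read-out lower numbers stand for an effect already at smaller amounts and higher numbers for an effect only at larger amounts of compound: compound 2 gives 8 mg/kg, while compound 1 `CC(C)(C)CC(C)(C)/N=C(\NC#N)Nc1cccnc1` gives 50 mg/kg, a gap beyond the scatter. Compound 3 `N#CN/C(=N\c1ccccc1)Nc1ccncc1` has not yet been measured in this assay. It differs from compound 2 in one place: phenyl in place of 1,2-dimethylbutyl on a double-bonded nitrogen. Among the measured compounds shown here, no measured pair isolates this change, so the direction is expectation only. The step is expected to run toward a higher minimum effective dose, a 2.5-fold higher number from compound 2 to compound 3 (0.40 log units; beyond the scatter), with wide uncertainty. Compound 3 is accordingly estimated at 20 mg/kg, within a range from 6 mg/kg to 60 mg/kg.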

Compound 3, minimum effective dose: 50 mg/kg
Estimate against measurement, compound 3: 2.5-fold (0.40 log units) below, within the range that was stated.
By their numbers in this assay, from the lowest: compound 2; then compounds 1 and 3 (each within the scatter of the next).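

Phenyl in place of 1,2-dimethylbutyl on a double-bonded nitrogen gives a 6.3-fold higher number from compound 2 to compound 3 (0.80 log units; beyond the scatter) in this assay and is the first single change read at this position. With the same heavy-atom count in both groups, the open branched chain gives the lower number in this one pair, so the position is sensitive to this exchange. Nothing measured here accounts for the step.

Going by these compounds, whether cyclohexyl or benzyl at this position would read closer to compound 2 or to compound 3 remains open. A single pair also leaves open whether the step holds on other cores.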